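Moving a Hydroxy Group onto a Second Sulfonamide Scaffold

The source may report more compounds than this note shows. Statements on the series, on what has been measured and on what is new or still open speak of the compounds shown alone.

Of the compounds shown here, three have been measured in a functional assay on A-375 cells (Homo sapiens) for antiproliferative activity, read by trypan blue exclusion, with a stated time of 48 h, tested at 1 uM; on this read-out higher numbers stand for a weaker effect at the one concentration tested and lower numbers for a stronger effect. Compound 1, `CCCCCCC#Cc1ccc(S(=O)(=O)Nc2cccc(-c3csc(NC(C)=O)n3)c2)cc1`, gives 40.7%. Compound 2, `CC(=O)Nc1nc(-c2cccc(NS(=O)(=O)c3ccc(C#CCO)cc3)c2)cs1`, differs from compound 1 in one place: hydroxy in place of pentyl on a saturated chain carbon bound to a triple-bonded carbon. In this assay compound 2 gives 81.3%. With this change the read-out rises, a number 40.6 percentage points higher from compound 1 to compound 2 (beyond the scatter), so compound 2 shows a clearly weaker effect than compound 1 at the one concentration tested. Compound 3, `CCCCCCC#Cc1cccc(S(=O)(=O)Nc2cccc(-c3csc(NC(C)=O)n3)c2)c1`, is built from the same atoms as compound 1 but joined differently; the difference between the two cores is not broken down here. In this assay compound 3 gives 56.9%, a number beyond the scatter from both compound 1 and compound 2.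

Compound 4, `CC(=O)Nc1nc(-c2cccc(NS(=O)(=O)c3cccc(C#CCO)c3)c2)cs1`, is not yet measured. It stands to compound 3 exactly as compound 2 stands to compound 1: hydroxy in place of pentyl on a saturated chain carbon bound to a triple-bonded carbon. This is the same change made on the other core, and among the compounds shown it occurs twice in all. Among the compounds with values here, the one measured example of this change is a large loss of effect, and compound 3 already starts at a weaker level than compound 1, so the expected step for compound 4 is of the same direction but somewhat smaller, a number 31.1 percentage points higher from compound 3 to compound 4 (beyond the scatter), since the read-out cannot move far beyond a complete loss of effect. On this basis compound 4 is estimated to give 88% in this assay, expected to fall between 70% and 100%.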

Compound 4, a percentage reported as activity, at one concentration (the size of the read-out at that concentration, not a potency): 85.4%
The estimate for compound 4 lay 2.6 percentage points above the measured number, and the stated range covers the measured number.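

In this assay the swap of pentyl for hydroxy weakens the effect on the core of compound 3 as it did on the core of compound 1, a number 28.5 percentage points higher from compound 3 to compound 4 (beyond the scatter), so the direction of the change carries over from one core to the other. The two steps also cannot be told apart in size: the same change on two cores in this assay, a number 40.6 percentage points higher (beyond the scatter) from compound 1 to compound 2 and a number 28.5 percentage points higher (beyond the scatter) from compound 3 to compound 4, 12.1 percentage points apart, within the scatter of two such steps This does not show that the change would behave the same way on any further core, since it rests on two pairs of compounds at a single concentration in one assay, and it gives no reason for the loss of effect.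

The change shortens the chain and brings in the hydroxy group at once, so the compounds shown leave open which of the two goes with the weaker effect; a methyl group in place of the hydroxy, on the same short chain, would separate them. They also leave open how an amine, a carboxylic acid or a chain of intermediate length such as propyl would behave at this same place, on a saturated chain carbon bound to a triple-bonded carbon.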